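The source may report more compounds than this note shows. Statements on the series, on what has been measured and on what is new or still open speak of the compounds shown alone.

Going by the values given here, in a physicochemical assay for solubility, at pH 7.4 (on this read-out lower numbers stand for lower solubility and higher numbers for higher solubility), compound 1 `Cc1ccc(NC(=O)Nc2cc(C)nc3ccccc23)cc1` gives 1300 nM and compound 2 `Cc1cc(NC(=O)Nc2ccccc2F)c2ccccc2n1` gives 3800 nM, the higher of the two numbers so far. Compound 3 `Cc1cc(NC(=O)Nc2ccc(Cl)cc2)c2ccccc2n1` carries this change from compound 2: 4-chlorophenyl in place of 2-fluorophenyl on an amide-type nitrogen. The 2-fluorophenyl leaves the amide-type nitrogen, and 4-chlorophenyl takes the place held by 4-methylphenyl in compound 1. Among the compounds with values here, the one measured step that bears on this is modest: a 2.9-fold higher number from compound 1 to compound 2 (0.47 log units; beyond the scatter). A modest fall of similar size is therefore expected in this assay, an estimated 2.9-fold lower number from compound 2 to compound 3 (0.47 log units; beyond the scatter). For compound 3 the estimated value is 1300 nM, with an expected range of 500 nM to 3200 nM.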

Compound 3, solubility: 1400 nM
Beside the measured number, compound 3's estimate is 1.1-fold (0.03 log units) below it; the range from low to high includes it.
By their numbers in this assay, from the lowest: compounds 1 and 3 (each within the scatter of the next); then compound 2.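

Chloro in place of methyl on an aromatic carbon gives a 1.1-fold higher number from compound 1 to compound 3 (0.03 log units; within the scatter), so this assay does not separate these two groups on the phenyl ring. Moving from 2-fluorophenyl to 4-chlorophenyl on the amide-type nitrogen gives a 2.7-fold lower number from compound 2 to compound 3 (0.43 log units; beyond the scatter), leaving 2-fluorophenyl as the only group here with both of its steps beyond the scatter. Nothing on hand accounts for these differences.

On these data alone, whether the higher number goes with the fluoro group itself or with its place on the phenyl ring remains open. Also open, as far as these compounds go, is how an amine or a carboxylic acid on that ring would read in this assay.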